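Swapping Fluoro for Methyl on the Sulfonamide Ring

The source may report more compounds than this note shows. Statements on the series, on what has been measured and on what is new or still open speak of the compounds shown alone.

Measured compounds:
compound 1 `Cc1ncc([N+](=O)[O-])n1CC(=O)NS(=O)(=O)c1ccc(F)cc1`, 1.26 ug/mL
compound 2 `O=C(Cc1ccc(F)cc1)NS(=O)(=O)c1ccc(Cl)cc1`, 6.28 ug/mL
compound 3 `O=C(Cc1ccc(F)cc1)NS(=O)(=O)c1ccc(F)cc1`, 5.64 ug/mL

In a functional assay on A549 cells (Homo sapiens) for antiproliferative activity, read by MTT assay, with a stated time of 48 h (on this read-out lower numbers stand for stronger inhibition and higher numbers for weaker inhibition), compound 3 gives 5.64 ug/mL, the second highest of the three numbers; compound 2 lies within the scatter of it, while compound 1 sits beyond the scatter at a lower number. Compound 4 `Cc1ccc(S(=O)(=O)NC(=O)Cc2ccc(F)cc2)cc1` differs from compound 3 by methyl in place of fluoro on an aromatic carbon. One measured step of the same kind bears on it: a 1.1-fold lower number from compound 2 to compound 3 (0.05 log units; within the scatter). Exchanging one small group for another at this place did not move the number beyond the scatter there, so the expected step of a 1.0-fold lower number from compound 3 to compound 4 (0.01 log units; within the scatter) is likewise judged small, with no direction beyond the scatter. Compound 4 is therefore expected to give about 5.5 ug/mL, within 2.5 ug/mL to 12 ug/mL.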

Compound 4, half-maximal inhibitory concentration: 12 ug/mL
Estimate against measurement, compound 4: 2.2-fold (0.34 log units) below, within the range that was stated.
By their numbers in this assay, from the lowest: compound 1; then compounds 3, 2 and 4 (each within the scatter of the next, the first and the last beyond it).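

In this assay, the group at this place can move the number beyond the scatter, if only modestly: methyl in place of fluoro gives a 2.1-fold higher number from compound 3 to compound 4 (0.33 log units; beyond the scatter), whereas methyl in place of chloro gives a 1.9-fold higher number from compound 2 to compound 4 (0.28 log units; within the scatter) and stays within it. Only fluoro and methyl are therefore told apart here, with chloro within the scatter of both. Nothing measured here accounts for this difference. Going by these compounds, how a methoxy group, an amine or a carboxylic acid at this place would read remains open. So does whether methyl in place of fluoro gives a similar step on the core of compound 1.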